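The source may hold more compounds than are shown below. What is called first, only, known or untested is meant among the compounds shown, and "the series" means these compounds.

In a functional assay on MDA-MB-436 cells (Homo sapiens) for antiproliferative activity, read by MTT assay, with a stated time of 24 h (on this read-out lower numbers stand for stronger inhibition and higher numbers for weaker inhibition), compound 1 (`O=C(O)CC(NS(=O)(=O)c1cc(F)cc(F)c1)c1ccccc1`) gives 69400 nM and compound 2 (`N#Cc1ccc(S(=O)(=O)NC(CC(=O)O)c2ccccc2F)cc1`) gives 77700 nM as numbers within the scatter of each other, so compound 2 stands level with compound 1. Compound 3 (`O=C(O)CC(NS(=O)(=O)c1cc(F)cc(F)c1)c1ccccc1F`) has 3,5-difluorophenyl in place of 4-cyanophenyl on a sulfonyl sulfur. For the measured compounds named here, no step between measured compounds is available. Compound 1 carries 3,5-difluorophenyl and sits at 69400 nM in this assay so no step beyond the scatter is expected. The estimated step is a 1.1-fold lower number from compound 2 to compound 3 (0.03 log units; within the scatter) and lies within the scatter. For compound 3 the expected value is 72000 nM with an estimated range from 35000 nM to 150000 nM in these notes.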

Compound 3, half-maximal inhibitory concentration: 89300 nM
Compound 3: the middle estimate sits 1.2-fold (0.09 log units) below what was measured; the range from low to high includes it.
By their numbers in this assay, from the lowest: compounds 1, 2 and 3 (each within the scatter of the next).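

In this assay, 3,5-difluorophenyl in place of 4-cyanophenyl on a sulfonyl sulfur gives a 1.1-fold higher number from compound 2 to compound 3 (0.06 log units; within the scatter), so these two groups cannot be told apart at this position. Fluoro in place of hydrogen on an aromatic carbon gives a 1.3-fold higher number from compound 1 to compound 3 (0.11 log units; within the scatter), so this second single change also produces no separation. No measurement on hand bears on what lies behind either step.

From the compounds shown here alone, whether an amine or a longer alkyl chain on a sulfonyl sulfur, in place of these substituted phenyl groups, would move the number beyond the scatter remains open.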